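The compounds below may be only part of what the source reports. "The series", "measured", "known", "first", "only" and "open" are said of these compounds alone.

Measured so far in a functional assay on MKN-74 cells (Homo sapiens) for inhibition, read by colorimetric assay and sulforhodamine B assay, with a stated time of 48 h; on this read-out higher numbers stand for weaker inhibition of growth and lower numbers for stronger inhibition of growth:
- Compound 1 `CCCCCCCCCCCC[C@@H](O)[C@H]1CC[C@H]([C@H](O)CCCCCCCCCCNC(=O)c2cncs2)O1`: 61700 nM
- Compound 2 `CCCCCCCCCCCC[C@@H](O)[C@H]1CC[C@H]([C@H](O)CCCCCCCCCCNC(=O)c2ccsc2)O1`: 1510 nM

Of these two, compound 2 has the lower number and so the stronger inhibition of growth. Compound 3 `CCCCCCCCCCCC[C@@H](O)[C@H]1CC[C@H]([C@H](O)CCCCCCCCCCNC(=O)c2ccnn2C)O1` has not yet been measured. It keeps the core of compound 2 and changes one group: 1-methyl-1H-pyrazol-5-yl in place of thiophen-3-yl on a carbonyl carbon. In words, 1-methyl-1H-pyrazol-5-yl takes the place of thiophen-3-yl on a carbonyl carbon.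

Among the measured compounds shown here, only one measured step bears on this change. It is a 41-fold lower number from compound 1 to compound 2 (1.61 log units; beyond the scatter), a large step well beyond the scatter, made by putting thiophen-3-yl in place of 1,3-thiazol-5-yl at this same place. So a single swap of this group can move the number a long way. Compound 3, like compound 1, lacks thiophen-3-yl, so a higher number is expected, though probably not the whole distance. One step is thin evidence, so the uncertainty is wide. The expected change is a 5.3-fold higher number from compound 2 to compound 3 (0.72 log units; beyond the scatter). For compound 3 the estimated value in this assay is 8000 nM, with an expected range from 1500 nM to 45000 nM.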

Compound 3, concentration for 50% growth inhibition: 3890 nM
Beside the measured number, compound 3's estimate is 2.1-fold (0.31 log units) above it, within the range that was stated.
By their numbers in this assay, from the lowest: compound 2; then compound 3; then compound 1.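

In this assay, the swap gives a 2.6-fold higher number from compound 2 to compound 3 (0.41 log units; beyond the scatter), a modest step, while the same ring compared with the other one gives a 16-fold lower number from compound 1 to compound 3 (1.20 log units; beyond the scatter), a large step. So the earlier picture, in which a single swap at this carbonyl carbon moved the number a long way, does not mean that every replacement for thiophen-3-yl costs that much: 1-methyl-1H-pyrazol-5-yl, whose ring holds nitrogen and no sulfur, stays far closer to thiophen-3-yl than to 1,3-thiazol-5-yl, and compound 1 shows that a sulfur-containing ring does not by itself give strong inhibition of growth. Nothing available explains why these three rings rank as they do.

From the compounds shown here alone, what the methyl group on the pyrazole ring contributes remains open, as does whether a plain phenyl ring or a furan-3-yl ring at this place would fall nearer compound 2 or compound 1. Going by these compounds, it is also open whether the same ranking of the rings would hold with a shorter chain between the amide and the shared core.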